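Replacing Aminophenyl with Nitrophenyl on a Shared Core

A few compounds are considered here, and "the series" means these few. Any claim that something is new, unique, unknown or untested is made for them only; others in the source may bear on it.

Of the compounds shown here, two built on one core have been measured in an assay on CHO cells for displacement of a labelled ligand from adenosine receptor A3 (Homo sapiens), read by scintillation counting; a higher number here means a weaker inhibitor, a lower number a stronger inhibitor. Compound 1 `CNC(=O)[C@@]12C[C@@H]1[C@@H](n1cnc3c(NCc4cccc(Cl)c4)nc(C#CCCCCc4cn(-c5ccc(N)cc5)nn4)nc31)[C@H](O)[C@@H]2O` gives 87.1 nM and holds the lowest of the two numbers. Among the compounds with values here, compound 2 `CNC(=O)[C@@]12C[C@@H]1[C@@H](n1cnc3c(NCc4cccc(Cl)c4)nc(C#CCCCCc4cn(-c5ccc(C(=O)O)cc5)nn4)nc31)[C@H](O)[C@@H]2O` gives 180 nM; the only change between them is carboxy in place of amino on an aromatic carbon, and it brings a 2.1-fold higher number from compound 1 to compound 2 (0.32 log units; beyond the scatter).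

Compound 3 `CNC(=O)[C@@]12C[C@@H]1[C@@H](n1cnc3c(NCc4cccc(Cl)c4)nc(C#CCCCCc4cn(-c5cccc([N+](=O)[O-])c5)nn4)nc31)[C@H](O)[C@@H]2O` has not yet been measured. It differs from compound 1 by 3-nitrophenyl in place of 4-aminophenyl on an aromatic nitrogen. Within the data shown here, no measured step makes this exact change, but the one step on record, a 2.1-fold higher number from compound 1 to compound 2 (0.32 log units; beyond the scatter), shows that altering the group on this aromatic carbon shifts the number only modestly. The nitro group enters at a different position on the phenyl ring and removes the hydrogen-bond donor that the amino group supplied, so the comparison is loose. On that basis compound 3 is expected to give 150 nM, between 60 nM and 400 nM, an estimated step of a 1.7-fold higher number from compound 1 to compound 3 (0.24 log units; within the scatter) toward a somewhat weaker inhibitor.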

Compound 3, inhibition constant: 10.6 nM
Beside the measured number, compound 3's estimate is 14-fold (1.15 log units) above it; measured number below the stated range.
By their numbers in this assay, from the lowest: compound 3; then compound 1; then compound 2.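

In this assay, the group on the aromatic nitrogen of the five-membered ring turns out to matter far more than the earlier pair could show: 3-nitrophenyl in place of 4-aminophenyl gives an 8.2-fold lower number from compound 1 to compound 3 (0.91 log units; beyond the scatter), and 3-nitrophenyl in place of 4-carboxyphenyl gives a 17-fold lower number from compound 2 to compound 3 (1.23 log units; beyond the scatter). Compound 3 is the stronger inhibitor in both steps, beyond the scatter, even though its 3-nitrophenyl group has no hydrogen-bond donor, so the hydrogen-bond donor of 4-aminophenyl is not required for a low number on this core. Nothing measured here accounts for the size of these steps.

Because the nitro group differs from the amino group in both identity and place on the phenyl ring, the compounds shown cannot say how much of the lower number comes from each. Also open, as far as these compounds go, is how this position would respond to an unsubstituted phenyl ring, or to a phenyl ring carrying a nitrile or a methoxy group, and whether any of these would match or improve on compound 3.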